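The compounds below may be only part of what the source reports. "The series", "measured", "known", "first", "only" and "open" are said of these compounds alone.

Of the compounds shown here, three built on one shared core have been tested in a functional assay on the whole organism for inhibition, with Rattus norvegicus as the target, read by cytopathic effect and paw edema, at a dose of 100 mg/kg by the oral route; on this read-out lower numbers stand for less inhibition and higher numbers for more inhibition at the one dose given (going by the name of the read-out). Compound 1 `COc1cccc(NC(=O)c2c(O)c3cccnc3n(-c3ccccc3)c2=O)c1` gives 20.7%. Compound 2 `O=C(Nc1cccc(Cl)c1)c1c(O)c2cccnc2n(-c2ccccc2)c1=O` carries chloro in place of methoxy on an aromatic carbon, and in this assay compound 2 gives 13.4%, a step of a number 7.3 percentage points lower from compound 1 to compound 2 (within the scatter). Compound 3 `COc1ccc(NC(=O)c2c(O)c3cccnc3n(-c3ccccc3)c2=O)cn1` differs from compound 1 by 6-methoxypyridin-3-yl in place of 3-methoxyphenyl on an amide-type nitrogen, and in this assay compound 3 gives -10.2%. Compound 4 `O=C(Nc1ccc(Cl)nc1)c1c(O)c2cccnc2n(-c2ccccc2)c1=O` is not yet measured; it differs from compound 3 by chloro in place of methoxy on an aromatic carbon. This is the same kind of change as from compound 1 to compound 2, but the place differs: earlier it sat on an aromatic carbon of a six-membered aromatic ring of carbon only, meta to a large group; here it sits on an aromatic carbon of a six-membered aromatic ring with one nitrogen, next to the ring nitrogen, para to a large group. That earlier step stayed within the scatter, so a similarly small step is expected, about a number 4.8 percentage points lower from compound 3 to compound 4 (within the scatter). Compound 4 is therefore expected to give -15%, somewhere between -35% and 5%.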

Compound 4, a percentage reported as inhibition, in the whole organism at one dose (the size of the read-out at that dose, not a potency): -4%
Beside the measured number, compound 4's estimate is 11 percentage points below it; the range from low to high includes it.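

In this assay, chloro in place of methoxy gives a number 6.2 percentage points higher from compound 3 to compound 4 (within the scatter), and set beside the earlier step, the two cores show no difference: the same change on two cores in this assay, a number 7.3 percentage points lower (within the scatter) from compound 1 to compound 2 and a number 6.2 percentage points higher (within the scatter) from compound 3 to compound 4, 13.5 percentage points apart, within the scatter of two such steps. The swap therefore stays a small step on both cores, but this does not prove that the two steps are equal, since a real difference could hide in the scatter, and two pairs make no general rule. The larger steps come with the group on the amide-type nitrogen: 6-chloropyridin-3-yl in place of 3-chlorophenyl gives a number 17.4 percentage points lower from compound 2 to compound 4 (beyond the scatter), and in place of 3-methoxyphenyl gives a number 24.7 percentage points lower from compound 1 to compound 4 (beyond the scatter).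

On these data alone, whether an amine or a nitrile at this place would behave like chloro or methoxy stays open. So does whether the swap would remain a small step on any other core.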